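This account rests on a few compounds, and the source may have more. Where it says the series, first, only, none or still open, it means among the compounds named here.

Compound 1 `CC(C)c1cccc(C(C)C)c1NC(=O)NS(=O)(=O)N(Cc1ccccc1)C(C)C`: 400 nM in an assay on liver for inhibition of sterol O-acyltransferase 1 (Rattus norvegicus), using microsomes; a higher number here means a weaker inhibitor, a lower number a stronger inhibitor
Compound 2 `CC(C)c1cccc(C(C)C)c1OC(=O)NS(=O)(=O)N1CCCCC1`: > 100000 nM in this assay

Compound 1 is a clear inhibitor in this assay. As far as these compounds go, compound 2, in contrast, gives only a limit in this assay, not a number, so its true potency is unknown; it sits at the limit of > 100000 nM in this assay, at which 1 of the 2 values shown sits. Compound 2 thus stands at the weak end of the two values shown. Compound 1 and compound 2 differ in more than one place, so their gap cannot be assigned to any single change.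

Compound 3 `CC(C)c1cccc(C(C)C)c1OC(=O)NS(=O)(=O)Nc1ccccc1` has not been measured. It differs from compound 2 by anilino in place of piperidin-1-yl on a sulfonyl sulfur whose other neighbour is an amide-type nitrogen. Going by the values given here, no step between measured compounds exists for this change, so its size is only an expectation: the step from compound 2 to compound 3 in this assay is estimated at an at least 3.3-fold lower number from compound 2 to compound 3 (0.52 log units; beyond the scatter), a gain beyond the scatter, although the outcome may again be only a limit. Compound 3 is expected to give about 30000 nM in this assay, within 2000 nM to 300000 nM.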

Compound 3, half-maximal inhibitory concentration: 38100 nM
For compound 3 the middle estimate is 1.3-fold (0.10 log units) below the measured one; measured number inside the range.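

Going by these compounds alone, this is the first step at this position that can be read: in this assay, anilino in place of piperidin-1-yl on a sulfonyl sulfur gives an at least 2.6-fold lower number from compound 2 to compound 3 (0.41 log units; beyond the scatter). This single change takes the core of compound 2 from a limit to a measured number, so the group on the sulfonyl sulfur can alter the read-out in this series. The step is a minimum and not a full size, because compound 2 has only a limit and not a number: the limit of > 100000 nM in this assay, at which 1 of the 3 values shown sits.

The change from piperidin-1-yl to anilino swaps a non-aromatic ring for an aromatic one and also adds a hydrogen-bond donor, and the compounds shown leave open which of these two differences goes with the gain. As far as these compounds go, a cyclohexylamino group, which has the hydrogen on its nitrogen but no aromatic ring, and a methyl(phenyl)amino group, which has the aromatic ring but no such hydrogen, would each carry only one of the two, and how either would compare with anilino remains unknown.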